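Replacing an aromatic amide group with a short chain

The source may hold more compounds than are shown below. What is called first, only, known or untested is meant among the compounds shown, and "the series" means these compounds.

Measured so far in a functional assay on HT-29 cells (Homo sapiens) for inhibition, read by MTT assay, with a stated time of 120 h (on this read-out higher numbers stand for weaker inhibition and lower numbers for stronger inhibition), are these compounds
Compound 1 `CC(NC(=O)CCc1ccc(NC(=O)Nc2ccc(Cl)c(C(F)(F)F)c2)cc1)c1ccccc1` gives 26500 nM
Compound 2 `CNC(=O)c1cccc(-c2ccc(NC(=O)Nc3ccc(Cl)c(C(F)(F)F)c3)cc2)c1` gives 29300 nM

Compound 2 stands level with compound 1, as their two values lie within the usual scatter of repeated measurements. Compound 3 `CNC(=O)CCc1ccc(NC(=O)Nc2ccc(Cl)c(C(F)(F)F)c2)cc1` has 2-(methylcarbamoyl)ethyl in place of 3-(methylcarbamoyl)phenyl on an aromatic carbon, so the six-membered aromatic ring of that group is lost.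

Within the data shown here, no measured pair shows this exact change. Still, compound 1 (26500 nM) and compound 2 (29300 nM) carry quite different groups at this place, yet their values do not differ beyond the scatter. A large shift therefore seems unlikely. The expected result in this assay is a 1.0-fold higher number from compound 2 to compound 3 (0.01 log units; within the scatter) and so no change beyond the scatter. Compound 3 is estimated at 30000 nM within an expected range of 13000 nM to 70000 nM overall.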

Compound 3, half-maximal inhibitory concentration: 20600 nM
Compound 3: middle estimate off by 1.5-fold (0.16 log units), on the high side, within the range that was stated.
By their numbers in this assay, from the lowest: compounds 3, 1 and 2 (each within the scatter of the next).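

In this assay, the step with 2-(methylcarbamoyl)ethyl in place of 3-(methylcarbamoyl)phenyl gives a 1.4-fold lower number from compound 2 to compound 3 (0.15 log units; within the scatter) and so shows directly that losing the six-membered aromatic ring of this group, together with its smaller size, leaves the number within the scatter. On the amide-type nitrogen of the chain, methyl in place of 1-phenylethyl gives a 1.3-fold lower number from compound 1 to compound 3 (0.11 log units; within the scatter) and so shows that this much smaller group makes no difference beyond the scatter either. No supporting measurement is available to explain this lack of change.

All three compounds shown carry an amide in this group, so it remains open whether a carboxylic acid or an amine there would shift the number. A longer chain between the amide and the aromatic ring also remains untested in the compounds shown.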